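Swapping chloro for methoxy in a cytotoxic indolinone series

This account rests on a few compounds, and the source may have more. Where it says the series, first, only, none or still open, it means among the compounds named here.

Measured so far:
- compound 1, `COc1c(/C=C2/C(=O)Nc3ccc(Cl)cc32)c2ccccc2n1-c1ccccc1`: 21900 nM
- compound 2, `O=C1/C(=C/c2c(Cl)[nH]c3ccccc23)c2ccccc2N1Cc1ccccc1`: 77600 nM

In a functional assay on cells (Cancer cell lines, Homo sapiens) for cytotoxicity, with a stated time of 48 h (on this read-out higher numbers stand for weaker inhibition of growth and lower numbers for stronger inhibition of growth), compound 1 gives 21900 nM, the lowest of the two numbers shown, and its nearest neighbour, compound 2, gives 77600 nM, a gap beyond the usual scatter. Compound 2 differs from compound 1 in several places at once, so no single structural step can be read from that pair.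

Compound 3, `COc1ccc2c(c1)/C(=C\c1c(OC)n(-c3ccccc3)c3ccccc13)C(=O)N2`, has not yet been tested. It differs from compound 1 by one change: methoxy in place of chloro on an aromatic carbon. Nothing measured here isolates the effect of this swap, so the expectation rests on compound 1 alone. The step from compound 1 to compound 3 is expected to be small, a 1.4-fold higher number from compound 1 to compound 3 (0.14 log units; within the scatter), most likely within or only slightly beyond the scatter, leaning toward weaker growth inhibition. Compound 3 is therefore estimated at 30000 nM, with a plausible range from 8000 nM to 90000 nM.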

Compound 3, concentration for total growth inhibition: 17400 nM
Compound 3: the middle estimate sits 1.7-fold (0.24 log units) above what was measured; low and high end bracket the measured number.
By their numbers in this assay, from the lowest: compounds 3 and 1 (each within the scatter of the next); then compound 2.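

Placing methoxy where chloro stood, on an aromatic carbon meta to a fused ring and para to a fused ring, gives a 1.3-fold lower number from compound 1 to compound 3 (0.10 log units; within the scatter) in this assay, so this read-out does not separate the two groups at this position. The place therefore accepts a group with two heavy atoms and one hydrogen-bond acceptor in place of a single chlorine atom with no acceptor, without a change beyond the scatter, something compound 1 on its own could not show. Nothing available here explains why the two groups read alike.

From the compounds shown here alone, whether an amine, a carboxylic acid or a longer chain such as ethoxy would also leave the number unchanged at this position remains open. Going by these compounds, it is also open whether the same swap would read alike on a core carrying different groups elsewhere, such as that of compound 2.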